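Swapping a cyanobenzyl for butyl on a sugar-bearing core

The source may hold more compounds than are shown below. What is called first, only, known or untested is meant among the compounds shown, and "the series" means these compounds.

Compound 1: `C=CCn1c(=O)n(CCCCCCCC)c2nc(N)nc(O)c21`; in a functional assay (B cells) with Mus musculus as the target (a higher number here means that more compound is needed for the effect, a lower number that less compound is needed), compound 1 gives 37 uM.
Compound 2: `N#Cc1cccc(Cn2c(=O)n(C3OC(CO)[C@@H](O)[C@H]3O)c3nc(N)nc(O)c32)c1`; in this assay compound 2 gives 3 uM.

Compound 2 stands at the lower of the two numbers, and compound 1 sits above it by a gap beyond the usual scatter. Compound 3 is `CCCCn1c(=O)n(C2OC(CO)[C@@H](O)[C@H]2O)c2nc(N)nc(O)c21`, differing from compound 2 in one place: propyl in place of 3-cyanophenyl on a saturated chain carbon bound to an aromatic nitrogen. Within the data shown here, no measured pair shows this change, so the step is uncertain. The expectation for the step of a 2.7-fold higher number from compound 2 to compound 3 (0.43 log units; beyond the scatter) is a moderate rise, smaller than the gap to compound 1. Compound 3 is expected to give 8 uM, with a range from 2 uM to 30 uM.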

Compound 3, concentration for half-maximal effect: 11 uM
The estimate for compound 3 lay 1.4-fold (0.14 log units) below the measured number; the range from low to high includes it.
By their numbers in this assay, from the lowest: compound 2; then compound 3; then compound 1.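

On the saturated chain carbon bound to an aromatic nitrogen, replacing 3-cyanobenzyl with butyl on the shared core gives, in this assay, a 3.7-fold higher number from compound 2 to compound 3 (0.56 log units; beyond the scatter). This position therefore responds to its substituent, yet the ringless butyl chain still leaves compound 3 at 11 uM, a modest change rather than a loss of the effect. Nothing shown here bears on the reason for this step.

Going by these compounds, whether the step follows the loss of the ring or of the nitrile remains open, and a plain benzyl group would separate the two. How a longer chain or an amine would behave at this position is also unknown.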